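Replacing One Group on a Carbonyl Carbon

The source may report more compounds than this note shows. Statements on the series, on what has been measured and on what is new or still open speak of the compounds shown alone.

For the measured compounds named here, in a physicochemical assay for solubility, read by nephelometry, in phosphate buffer, measured as kinetic solubility, with a stated time of 30 min, at pH 6.5 (a lower number here means a less soluble compound, a higher number a more soluble compound), compound 2 `O=C(O)CNC(=O)COc1ccc([C@H]2CC[C@]3(CC2)OOC2(O3)C3CC4CC(C3)CC2C4)cc1` gives 12.5 ug/mL, the only true number so far. Compound 1 `O=C(O)COc1ccc([C@H]2CC[C@]3(CC2)OOC2(O3)C3CC4CC2CC(C3)C4O)cc1` reads < 1.6 ug/mL, which is a limit. Compound 3 `O=C(O)c1cccc([C@H]2CC[C@]3(CC2)OOC2(O3)C3CC4CC(C3)CC2C4)c1` reads < 1.6 ug/mL, also a limit. The readings are therefore thin, with the limit of < 1.6 ug/mL in this assay, at which 2 of the 3 values shown sit.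

Compound 4 `CCOC(=O)COc1ccc([C@H]2CC[C@]3(CC2)OOC2(O3)C3CC4CC(C3)CC2C4)cc1` carries ethoxy in place of (carboxymethyl)amino on a carbonyl carbon. Going by the values given here, no measured pair shows this change, so its size is a judgement. A clear drop beyond the scatter in this assay is expected, since only compound 2 at 12.5 ug/mL rises to a readable number. The expected change is a 7.8-fold lower number from compound 2 to compound 4 (0.89 log units; beyond the scatter). For compound 4 the estimate is 1.6 ug/mL, with an expected range of 1 ug/mL to 4 ug/mL. The assay may well report only a limit.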

Compound 4, solubility: < 1.6 ug/mL
Compound 4 gave a limit, no number (the forecaster's own chance of this, stated with the estimate: 70%); the middle value sits exactly at the limit.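

In this assay, for the compounds shown here, this is the first pair differing in one place, and on this carbonyl carbon ethoxy in place of (carboxymethyl)amino gives an at least 7.8-fold lower number from compound 2 to compound 4 (0.89 log units; beyond the scatter). The reading for compound 4 is a limit, so the step has a minimum size but no exact one. Compound 2 remains the only compound with a readable number: the limit of < 1.6 ug/mL in this assay, at which 3 of the 4 values shown sit.

Which part of (carboxymethyl)amino accounts for the step stays open. Methylamino on the same carbonyl carbon would separate the contribution of the amide nitrogen from that of the carboxymethyl end.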